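Pyrazinyl in Place of Methoxyphenyl on a Ring Amine

The source may report more compounds than this note shows. Statements on the series, on what has been measured and on what is new or still open speak of the compounds shown alone.

Measured compounds:
compound 1, `COc1ccc(N2CCN(C(=S)SCc3ccc(C(=O)Nc4ccccc4N)cc3)CC2)cc1`, 39.4%
compound 2, `Nc1ccccc1NC(=O)c1ccc(CSC(=S)N2CCCc3ccccc32)cc1`, 26.1%

In a functional assay on HeLa cells (Homo sapiens) for antiproliferative activity, read by CCK-8 assay, with a stated time of 72 h, tested at 2 uM (a lower number here means a weaker effect, a higher number a stronger effect of the compound at the concentration tested), compound 1 gives 39.4%, the higher of the two numbers available. Compound 2 gives 26.1%, and that number lies below compound 1 by more than the usual scatter of this kind of measurement. Both share the same core; they differ in the group attached to the thiocarbonyl.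

Compound 3, `Nc1ccccc1NC(=O)c1ccc(CSC(=S)N2CCN(c3cnccn3)CC2)cc1`, has not yet been measured. It differs from compound 1 in one place: pyrazin-2-yl in place of 4-methoxyphenyl on an amine nitrogen in a ring. Within the data shown here, no two measured compounds differ from each other in a single place, so the size of such a step cannot be read from any measured pair. The expectation for this change is a small step downward in this assay, one that stays within the usual scatter. Compound 3 is therefore estimated at 33%, with a likely range from 17% to 49%. This estimate corresponds to an expected step of a number 6.4 percentage points lower from compound 1 to compound 3 (within the scatter).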

Compound 3, a percentage reported as inhibition, at one concentration (the size of the read-out at that concentration, not a potency): 70.4%
Compound 3: the middle estimate sits 37.4 percentage points below what was measured, and the stated range ends below it.
By their numbers in this assay, from the lowest: compound 2; then compound 1; then compound 3.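

In this assay, pyrazin-2-yl in place of 4-methoxyphenyl on an amine nitrogen in a ring gives a number 31 percentage points higher from compound 1 to compound 3 (beyond the scatter). Among these compounds, this is the first single-place step available, and it shows that the group on this nitrogen can change the read-out by far more than the usual scatter. No measurement shown here explains why this change has such a large effect.

The compounds shown leave open whether the step follows from the two ring nitrogens that enter or from the loss of the methoxy group, and a plain phenyl or a pyridin-2-yl on the same nitrogen would help to separate the two. Also open, going by these compounds, is whether the same step would appear at other concentrations, since a reading at one concentration is not a potency.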